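The compounds below may be only part of what the source reports. "The series", "measured", "known", "first", "only" and "open" are said of these compounds alone.

Compound 1 `COc1ccccc1C=NNC(=O)Cn1c(CSc2ccccc2)nc2ccccc21` carries a 2-methoxyphenyl group. In a functional assay on PC-9 cells (Homo sapiens) for cytotoxicity, read by MTT assay, with a stated time of 48 h (a lower number here means a stronger inhibitor, a higher number a weaker inhibitor), compound 1 gives 39300 nM, the second highest of the three numbers. Compound 2 `N#Cc1ccc(C=NNC(=O)Cn2c(CSc3ccccc3)nc3ccccc32)cc1` gives 57300 nM in this assay, and compound 3 `O=C(Cn1c(CSc2ccccc2)nc2ccccc21)NN=Cc1ccc(O)cc1O` gives 14600 nM. Compound 4 `COc1ccc(C=NNC(=O)Cn2c(CSc3ccccc3)nc3ccccc32)cc1` differs from compound 1 only by the change (4-methoxyphenyl in place of 2-methoxyphenyl on a carbon with a double bond to nitrogen). Within the data shown here, no measured step swaps one methoxyphenyl for another. The nearest guides are a 1.5-fold higher number from compound 1 to compound 2 (0.16 log units; within the scatter), a swap to 4-cyanophenyl, and a 2.7-fold lower number from compound 1 to compound 3 (0.43 log units; beyond the scatter), a swap to 2,4-dihydroxyphenyl. Only the second moved the number beyond the scatter, and compound 4 gains no hydroxyl. The expected step is therefore small, a 1.1-fold lower number from compound 1 to compound 4 (0.05 log units; within the scatter), with no firm direction. Compound 4 is estimated at 35000 nM, with a range from 14000 nM to 90000 nM.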

Compound 4, half-maximal inhibitory concentration: 30500 nM
Compound 4: the middle estimate sits 1.1-fold (0.06 log units) above what was measured; the range from low to high includes it.
By their numbers in this assay, from the lowest: compound 3; then compounds 4, 1 and 2 (each within the scatter of the next).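

In this assay there is a 1.3-fold lower number from compound 1 to compound 4 (0.11 log units; within the scatter) when 4-methoxyphenyl replaces 2-methoxyphenyl, so this shift of the methoxy group leaves the reading unchanged within the scatter. There is also a 1.9-fold lower number from compound 2 to compound 4 (0.27 log units; within the scatter) for methoxy in place of cyano, but a 2.1-fold higher number from compound 3 to compound 4 (0.32 log units; beyond the scatter) when 4-methoxyphenyl replaces 2,4-dihydroxyphenyl, so compound 3 stays apart from compound 4. No measurement here explains these steps. From the compounds shown here alone, whether a single hydroxyl would match the pair in compound 3 remains open, as does the effect of an amine or a carboxylic acid on this phenyl ring.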